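Series notes: aryl swap at the alkene terminus

A few compounds are considered here, and "the series" means these few. Any claim that something is new, unique, unknown or untested is made for them only; others in the source may bear on it.

Compound 1 `Fc1ccccc1/C=C/c1nnc(-c2ccc3c(c2)OCCO3)o1` is the reference point here. In a functional assay on HUVEC cells (Homo sapiens) for antiproliferative activity, read by MTT assay, with a stated time of 48 h (on this read-out higher numbers stand for weaker inhibition and lower numbers for stronger inhibition), compound 1 gives 1160 nM, the lowest of the two numbers in hand. Going by the values given here, its one measured neighbour, compound 2 `Clc1ccc(/C=C/c2nnc(-c3ccc4c(c3)OCCO4)o2)cc1`, gives 8030 nM in this assay, and the step of a 6.9-fold higher number from compound 1 to compound 2 (0.84 log units; beyond the scatter) shows that replacing the 2-fluorophenyl group weakened inhibition well beyond the scatter.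

Compound 3 `Cc1cccc(/C=C/c2nnc(-c3ccc4c(c3)OCCO4)o2)c1` differs from compound 1 by 3-methylphenyl in place of 2-fluorophenyl on a double-bonded chain carbon bound to a double-bonded chain carbon. Among the compounds with values here, the only step that bears on this change is the aryl replacement from compound 1 to compound 2, and it was modest but clear. A 3-methylphenyl group is a different replacement from 4-chlorophenyl, so the expected step is smaller and less certain; an increase in number is expected because a 6.9-fold higher number from compound 1 to compound 2 (0.84 log units; beyond the scatter) went that way. The estimate for compound 3 is 3000 nM, within 1000 nM to 10000 nM, corresponding to an expected step of a 2.6-fold higher number from compound 1 to compound 3 (0.41 log units; beyond the scatter).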

Compound 3, half-maximal inhibitory concentration: 40600 nM
Estimate against measurement, compound 3: 14-fold (1.13 log units) below; measured number outside the range, above it.
By their numbers in this assay, from the lowest: compound 1; then compound 2; then compound 3.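

In this assay the aryl group on a double-bonded chain carbon bound to a double-bonded chain carbon proves strongly sensitive to replacement: a 35-fold higher number from compound 1 to compound 3 (1.54 log units; beyond the scatter) is a large loss, well past the earlier chlorine swap. The two replacements are also not interchangeable, as a 5.1-fold higher number from compound 2 to compound 3 (0.70 log units; beyond the scatter) makes 3-methylphenyl the weakest of the three groups and leaves 2-fluorophenyl the strongest. Nothing available explains this order.

Going by these compounds, the three groups change both the substituent and its numbered ring position at once, so it remains open which of the two governs the number. Pairs such as 2-fluorophenyl with 3-fluorophenyl, or 3-methylphenyl with 2-methylphenyl, would separate these, and an unsubstituted phenyl would give a baseline for all of them.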